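The source may report more compounds than this note shows. Statements on the series, on what has been measured and on what is new or still open speak of the compounds shown alone.

Compound 1 `Cn1nnnc1SCC(=O)N/N=C/c1ccc([N+](=O)[O-])cc1` gives 632000 nM in a functional assay on A549 cells (Homo sapiens) for cytotoxicity, read by XTT assay, with a stated time of 24 h; a lower number here means a stronger inhibitor, a higher number a weaker inhibitor. Compound 2 `Cn1nnnc1SCC(=O)N/N=C/c1ccc(F)cc1` gives 3160000 nM in this assay. The change between them is fluoro in place of nitro on an aromatic carbon, and it produced a 5.0-fold higher number from compound 1 to compound 2 (0.70 log units; beyond the scatter). Compound 3 `Cn1nnnc1SCC(=O)N/N=C/c1cccc([N+](=O)[O-])c1` has the same atoms as compound 1, joined differently; how the two cores differ is not broken down here. In this assay compound 3 gives only a limit, > 10000000 nM, which is the limit of > 10000000 nM in this assay, at which 1 of the 3 values shown sits. Compound 4 `Cn1nnnc1SCC(=O)N/N=C/c1cccc(F)c1` is not yet measured; it differs from compound 3 by fluoro in place of nitro on an aromatic carbon, the same kind of change as seen from compound 1 to compound 2, the place here reading meta to a large group rather than para to a large group. Resting on a 5.0-fold higher number from compound 1 to compound 2 (0.70 log units; beyond the scatter) and on the limit reached by compound 3, compound 4 is expected to give 20000000 nM in this assay, most likely again as a limit. The step from compound 3 to compound 4 is estimated at a step that the limit leaves unreadable from compound 3 to compound 4.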

Compound 4, half-maximal inhibitory concentration: 6320000 nM
Beside the measured number, compound 4's estimate is 3.2-fold (0.50 log units) above it; the range from low to high includes it.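

In this assay, fluoro in place of nitro on an aromatic carbon gives an at least 1.5-fold lower number from compound 3 to compound 4 (0.19 log units; that floor lies within the scatter), while the same change on the other core gives a 5.0-fold higher number from compound 1 to compound 2 (0.70 log units; beyond the scatter). The change therefore does not carry over as one fixed step between these two cores: the same change on two cores in this assay, a 5.0-fold higher number (0.70 log units; beyond the scatter) from compound 1 to compound 2 and an at least 1.5-fold lower number (0.19 log units; that floor lies within the scatter) from compound 3 to compound 4, at least 7.9-fold (0.89 log units) apart, beyond the scatter of two such steps. The true size of the newer step is not shown, as compound 3 is held only as a limit: the limit of > 10000000 nM in this assay, at which 1 of the 4 values shown sits.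

Whether the difference follows the place of the group, meta to a large group rather than para to a large group, rests on these two pairs alone. Also open, on these data alone, is how an amine or a carboxylic acid on the same aromatic carbon would read on either core.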